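Triazole series: para substituent of the N-aryl ring

This account rests on a few compounds, and the source may have more. Where it says the series, first, only, none or still open, it means among the compounds named here.

In a functional assay on PC-12 cells (Rattus norvegicus) for cytotoxicity, read by MTT assay, with stated times of 2 h and 24 h, tested at 1 uM (on this read-out higher numbers stand for a stronger effect at the one concentration tested and lower numbers for a weaker effect), compound 1 `Oc1cc(C(F)(F)F)ccc1-c1nc(-c2ccccc2O)n(-c2ccc(I)cc2)n1` gives 70.1%; compound 2 `COc1ccc(-n2nc(-c3ccc(C(F)(F)F)cc3O)nc2-c2ccccc2O)cc1` gives 69% and compound 3 `Oc1cc(C(F)(F)F)ccc1-c1nc(-c2ccccc2O)n(-c2ccc(OC(F)(F)F)cc2)n1` gives 65.5%. Compound 1 gives the largest of the three numbers, but the steps of a number 1.1 percentage points lower from compound 1 to compound 2 (within the scatter) and a number 4.6 percentage points lower from compound 1 to compound 3 (within the scatter) both lie within the scatter, as does a number 3.5 percentage points lower from compound 2 to compound 3 (within the scatter). Compound 4 `Oc1cc(C(F)(F)F)ccc1-c1nc(-c2ccccc2O)n(-c2ccc(F)cc2F)n1` differs from compound 1 in one place: 2,4-difluorophenyl in place of 4-iodophenyl on an aromatic nitrogen. The two measured steps from compound 1 touch the same aryl group and neither moved this assay beyond the scatter, so no step beyond the scatter is expected for compound 4 either, if anything a slight drop, a number 4.1 percentage points lower from compound 1 to compound 4 (within the scatter). Compound 4 is therefore expected at 66% in this assay, with a range from 56% to 76%.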

Compound 4, a percentage reported as activity, at one concentration (the size of the read-out at that concentration, not a potency): 65.9%
The estimate for compound 4 lay 0.1 percentage points above the measured number; the measured number falls inside the stated range.
By their numbers in this assay, from the lowest: compounds 3, 4, 2 and 1 (each within the scatter of the next).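

Within the data shown here, with 2,4-difluorophenyl, the first group here with two substituents on this aryl ring, the read-out in this assay stays within the scatter of all three earlier compounds: a number 4.2 percentage points lower from compound 1 to compound 4 (within the scatter), a number 3.1 percentage points lower from compound 2 to compound 4 (within the scatter) and a number 0.4 percentage points higher from compound 3 to compound 4 (within the scatter). Replacing a single substituent on the aryl group on the aromatic nitrogen with two fluorines therefore gives no step beyond the scatter. Nothing available explains this flat picture. As far as these compounds go, whether an amine or a carboxylic acid on this aryl ring would move the number beyond the scatter remains open. A single concentration also leaves potency open.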